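A sulfur substituent swap from compound 2 to compound 3

The source may report more compounds than this note shows. Statements on the series, on what has been measured and on what is new or still open speak of the compounds shown alone.

- Compound 1 `COC(=O)c1ccc(C(=O)/C(=C\c2ccc(F)c([N+](=O)[O-])c2)SCc2ccc(Br)cc2)cc1` in a physicochemical assay for solubility (on this read-out higher numbers stand for higher solubility and lower numbers for lower solubility), gives < 1000 ug/mL as a limit
- Compound 2 `O=C(O)c1ccc(C(=O)/C(=C\c2ccc(F)c([N+](=O)[O-])c2)Sc2ccc(Br)cc2)cc1` in this assay gives < 1000 ug/mL as a limit

Compound 2 stands at < 1000 ug/mL as a limit of the assay and not a number. The data hold only the limit of < 1000 ug/mL in this assay, at which 2 of the 2 values shown sit, and no exact reading. Compound 3 `O=C(O)c1ccc(C(=O)/C(=C\c2ccc(F)c([N+](=O)[O-])c2)SCc2ccccc2Cl)cc1` brings one change, 2-chlorobenzyl in place of 4-bromophenyl on a sulfur in words 2-chlorobenzyl in place of 4-bromophenyl on a sulfur. No measured step sizes this change, so no shift beyond the scatter is expected in this assay and no direction can be told. The expected step runs a step that the limit leaves unreadable from compound 2 to compound 3 as an estimate only. Compound 3 is expected at 500 ug/mL with an estimated range of 100 ug/mL to 1000 ug/mL.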

Compound 3, solubility: < 1000 ug/mL
Compound 3: only a limit was reported (the forecaster's own chance of this, stated with the estimate: 75%); the middle value does not contradict the limit.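

In this assay no new step can be read from compound 2 to compound 3, as both values are limits: the limit of < 1000 ug/mL in this assay, at which 3 of the 3 values shown sit. The compounds shown leave open whether 2-chlorobenzyl in place of 4-bromophenyl on a sulfur shifts this read-out at all.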